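Phenyl in Place of Phenethyl: An Unchanged Dissociation Constant

The source may report more compounds than this note shows. Statements on the series, on what has been measured and on what is new or still open speak of the compounds shown alone.

Compound 1 `c1ccc(CCc2ccc3c(NCCCNCc4ccco4)ccnc3c2)cc1` and compound 2 `c1ccc(-c2ccc3c(NCCCNCc4ccco4)ccnc3c2)cc1` share one core and differ only in the change (phenyl in place of phenethyl on an aromatic carbon). In a physicochemical assay for acid dissociation, compound 1 gives 9.47, and compound 2 gives 9.47; the step of no change at the digits printed from compound 1 to compound 2 (within the scatter). Compound 3 `COc1ccc(F)cc1CNCCCNc1ccnc2cc(CCc3ccccc3)ccc12` carries a different core, and its difference from compound 1 is 5-fluoro-2-methoxyphenyl in place of furan-2-yl on a saturated chain carbon bound to an amine nitrogen. In this assay compound 3 gives 9.47, and the step of no change at the digits printed from compound 1 to compound 3 (within the scatter). Compound 4 `COc1ccc(F)cc1CNCCCNc1ccnc2cc(-c3ccccc3)ccc12` has not yet been measured in this assay. It differs from compound 3 in the change (phenyl in place of phenethyl on an aromatic carbon), which is the same change as that made from compound 1 to compound 2, at the same place on the core. Because compound 3 stands at 9.47, level with compounds 1 and 2, and because the earlier step of no change at the digits printed from compound 1 to compound 2 (within the scatter) stayed within the scatter, the same size of step is expected for compound 4: no change at the digits printed from compound 3 to compound 4 (within the scatter). Compound 4 is therefore estimated at 9.47, expected to fall between 9.2 and 9.75.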

Compound 4, acid dissociation constant: 9.47
For compound 4 middle estimate and measured number coincide at the digits printed, within the range that was stated.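

In this assay, placing phenyl where phenethyl stood on the core of compound 3 gives no change at the digits printed from compound 3 to compound 4 (within the scatter), the same outcome as no change at the digits printed from compound 1 to compound 2 (within the scatter) on the core of compound 1. The other side of the square agrees: with phenyl on the aromatic carbon, 5-fluoro-2-methoxyphenyl in place of furan-2-yl gives no change at the digits printed from compound 2 to compound 4 (within the scatter), so across these four compounds neither change shows up in the read-out and the two changes carry over from one core to the other with the same result. This holds for two cores and one read-out only, so it does not show that the change would behave alike on any further core, and no accompanying measurement bears on why the four values are level.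

The compounds shown carry only phenyl or phenethyl on that aromatic carbon, and they leave open whether an amine or a carboxylic acid there would stay level with them. They also leave open whether a longer chain in place of phenethyl would do so.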